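This account rests on a few compounds, and the source may have more. Where it says the series, first, only, none or still open, it means among the compounds named here.

Working notes on the series. Compound 2 `CC(=O)n1cc(/C=C(/C(=O)O)c2ccc(Cl)cc2)c2cc(OCc3ccccc3)ccc21` gives 52300 nM in a functional assay on A549 cells (Homo sapiens) for cytotoxicity, read by MTT assay, with a stated time of 72 h (a higher number here means a weaker inhibitor, a lower number a stronger inhibitor), the highest of the two numbers available; the nearest is compound 1 `COc1cc(OC)cc(/C(=C\c2cn(C(C)=O)c3ccc(OCc4ccccc4)cc23)C(=O)O)c1`, which gives 26000 nM, and the step of a 2.0-fold higher number from compound 1 to compound 2 (0.30 log units; within the scatter) lies within the scatter. Compound 3 `O=C(O)/C(=C/c1c[nH]c2ccc(OCc3ccccc3)cc12)c1ccccc1` gives "not determined" (no result reported) in this assay, so no number is available for it. The next step goes from compound 2 to compound 4 `COc1ccc(/C(=C\c2cn(C(C)=O)c3ccc(OCc4ccccc4)cc23)C(=O)O)cc1OC`: 3,4-dimethoxyphenyl in place of 4-chlorophenyl on a double-bonded chain carbon bound to a carbonyl carbon and a double-bonded chain carbon. Within the data shown here, the only measured step touching this position, a 2.0-fold higher number from compound 1 to compound 2 (0.30 log units; within the scatter), swapped a dimethoxyphenyl for the 4-chlorophenyl with no change beyond the scatter, so returning to a dimethoxyphenyl is expected to move the number little, if anything downward. Compound 4 is therefore estimated at 30000 nM, with a range of 10000 nM to 90000 nM, an expected step of a 1.7-fold lower number from compound 2 to compound 4 (0.24 log units; within the scatter).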

Compound 4, half-maximal inhibitory concentration: 54800 nM
The estimate for compound 4 lay 1.8-fold (0.26 log units) below the measured number; the measured number falls inside the stated range.
By their numbers in this assay, from the lowest: compounds 1, 2 and 4 (each within the scatter of the next, the first and the last beyond it).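

Between 4-chlorophenyl and 3,4-dimethoxyphenyl, this position shows no difference in this assay (a 1.0-fold higher number from compound 2 to compound 4 (0.02 log units; within the scatter)). Among these compounds, the first step here beyond the scatter, though modest, comes instead from exchanging 3,5-dimethoxyphenyl for 3,4-dimethoxyphenyl (a 2.1-fold higher number from compound 1 to compound 4 (0.32 log units; beyond the scatter)), so the two dimethoxyphenyl groups are not interchangeable at this place. No available evidence accounts for either step. The compounds shown leave open whether a group of another kind at this place, such as a 4-aminophenyl or a 4-cyanophenyl, would move the number further.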